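The compounds below may be only part of what the source reports. "The series", "measured", "known", "first", "only" and "open" are said of these compounds alone.

Measured so far:
- compound 1, `CC(C(=O)N1CCN(c2ccccc2)CC1)N1C(=O)CCC1=O`: 165 mg/kg in a functional assay on the whole organism (strain Swiss) with Mus musculus as the target, in the maximal electroshock model, with a stated time of 0.25 h; on this read-out higher numbers stand for an effect only at larger amounts of compound and lower numbers for an effect already at smaller amounts
- compound 2, `CCC(C(=O)N1CCN(c2cccc(C(F)(F)F)c2)CC1)N1C(=O)CCC1=O`: 58.9 mg/kg in this assay

Of the two numbers at hand, compound 2 stands lowest; compound 1 is the nearest, with a higher number, a gap that lies beyond the usual scatter. The unmeasured compound 3, `CCC(C(=O)N1CCN(c2ccccc2)CC1)N1C(=O)CCC1=O`, is reached from compound 2 by a single change: hydrogen in place of trifluoromethyl on an aromatic carbon. Among the compounds with values here, no step between measured compounds isolates this change. Since compound 1, which also bears hydrogen at this place, gives 165 mg/kg, a moderate rise in the number for compound 3 is expected, close to the edge of the scatter. The estimated step of a 1.7-fold higher number from compound 2 to compound 3 (0.23 log units; within the scatter) puts the expected dose for compound 3 at 100 mg/kg, within a range from 50 mg/kg to 200 mg/kg.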

Compound 3, dose for half-maximal effect: 149 mg/kg
Estimate against measurement, compound 3: 1.5-fold (0.17 log units) below; measured number inside the range.
By their numbers in this assay, from the lowest: compound 2; then compounds 3 and 1 (each within the scatter of the next).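

In this assay, within the data shown here, hydrogen in place of trifluoromethyl on the aromatic carbon gives a 2.5-fold higher number from compound 2 to compound 3 (0.40 log units; beyond the scatter) and so isolates this place for the first time: the change alone separates the two compounds by more than the scatter, with trifluoromethyl on the side of the lower number. Methyl in place of hydrogen on the saturated chain carbon gives a 1.1-fold lower number from compound 1 to compound 3 (0.04 log units; within the scatter) and cannot be told from the scatter, so this chain change shows no effect of its own in this pair. Nothing at hand gives a reason for the step at the aromatic carbon.

On these data alone, whether a chlorine atom, a methoxy group or a nitrile at this same place would match trifluoromethyl remains open. So does whether a longer chain on the saturated carbon would move the number, and whether trifluoromethyl brings a step of like size on the core of compound 1.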